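Pyrazole aryl swap, cytotoxicity near the assay ceiling

The source may hold more compounds than are shown below. What is called first, only, known or untested is meant among the compounds shown, and "the series" means these compounds.

Measured so far in an ADME assay on Huh-7 cells (Homo sapiens) for cytotoxicity; on this read-out lower numbers stand for higher toxicity in this test and higher numbers for lower toxicity in this test:
- compound 1 `Cc1ccccc1-c1nn(-c2ccc(Cl)cc2)cc1CNCCN1CCN(C)CC1`: 17000 nM
- compound 2 `Cc1ccccc1-c1nn(-c2ccc(F)cc2F)cc1CNCCN1CCN(C)CC1`: a limit, > 20000 nM
- compound 3 `Cc1ccc(-n2cc(CNCCN3CCN(C)CC3)c(-c3ccccc3C)n2)c(C)c1`: a limit, > 20000 nM

Compound 3 stands only as a limit in this assay; its value is not a number but the point at which the read-out stops, and compound 2 sits at that same limit (the limit of > 20000 nM in this assay, at which 2 of the 3 values shown sit). Compound 1 is the only one of the three with a numeric value, and it lies close to that ceiling.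

Compound 4 `Cc1ccccc1-c1nn(-c2ccc(OC(F)(F)F)cc2)cc1CNCCN1CCN(C)CC1` has not been measured. It differs from compound 3 in one place: 4-(trifluoromethoxy)phenyl in place of 2,4-dimethylphenyl on an aromatic nitrogen. The measured steps that bear on this kind of change are the aryl swaps on the same aromatic nitrogen. The step of an at least 1.1-fold higher number from compound 1 to compound 2 (0.07 log units; that floor lies within the scatter) and the step of an at least 1.1-fold higher number from compound 1 to compound 3 (0.07 log units; that floor lies within the scatter) both give only a floor that lies within the scatter, and the step that the two limits leave unreadable from compound 2 to compound 3 is unreadable because both ends are limits (the limit of > 20000 nM in this assay, at which 2 of the 3 values shown sit). None of these steps shows movement beyond the scatter, so no step beyond the scatter is expected in this assay for the change to compound 4 either.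

Compound 4 is therefore estimated at 20000 nM, in a range from 10000 nM to 40000 nM, which corresponds to the expected step of a number no higher from compound 3 to compound 4 (the limit leaves the size open).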

Compound 4, half-maximal cytotoxic concentration: 17000 nM
For compound 4 the middle estimate is 1.2-fold (0.07 log units) above the measured one, and the stated range covers the measured number.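

In this assay, within the data shown here, trifluoromethoxy in place of chloro on an aromatic carbon gives no change at the digits printed from compound 1 to compound 4 (within the scatter), the first step with a number at both ends. Measured against the two compounds held at a limit, the 4-(trifluoromethoxy)phenyl group on the aromatic nitrogen gives an at least 1.1-fold lower number from compound 3 to compound 4 (0.07 log units; that floor lies within the scatter) and an at least 1.1-fold lower number from compound 2 to compound 4 (0.07 log units; that floor lies within the scatter), so both steps supply only a floor, even though this group brings a hydrogen-bond acceptor that 2,4-dimethylphenyl does not have. The series now has two numeric values that do not differ at the digits printed, while the other two compounds remain limits and not numbers: the limit of > 20000 nM in this assay, at which 2 of the 4 values shown sit.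

On these data alone, how far compound 2 and compound 3 lie beyond that limit stays unknown, and the step between them cannot be read. The four aryl groups shown also leave open whether an amine or a carboxylic acid on this aryl ring, or a longer chain on the aromatic nitrogen, would move the read-out beyond the scatter.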